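Working notes: from compound 3 to the untested compound 4

The source may hold more compounds than are shown below. What is called first, only, known or untested is meant among the compounds shown, and "the series" means these compounds.

Measured to date in an assay for inhibition of 15-hydroxyprostaglandin dehydrogenase [NAD(+)] (Homo sapiens), read by fluorescence and spectrophotometry; on this read-out higher numbers stand for weaker inhibition and lower numbers for stronger inhibition:
compound 1 `O=C1N=C(O)S/C1=C\c1ccc(OCCc2ccccn2)cc1Cl` gives 8920 nM
compound 2 `O=C1NC(=O)/C(=C/c2ccc(OCCOC3CCCCC3)c(Cl)c2)S1` gives 20 nM
compound 3 `O=C1NC(=O)/C(=C/c2ccc(OCC3CCC3)c(Cl)c2)S1` gives 9 nM

Compound 3 holds the lowest number of the three. Among the measured compounds shown here, compound 1, with a different arrangement of the shared core, lies far away, while compound 2 is the nearest neighbour; the single step at the position in question is a 2.2-fold lower number from compound 2 to compound 3 (0.35 log units; beyond the scatter), a modest shift favouring the smaller group. Compound 4 `O=C1NC(=O)/C(=C/c2ccc(OCC3CC4CCC3C4)c(Cl)c2)S1` differs from compound 3 by a group of 7 heavy atoms (7 carbon; 2 five-membered non-aromatic rings of carbon only) in place of a group of 4 heavy atoms (4 carbon; one four-membered non-aromatic ring of carbon only), on a saturated chain carbon bound to an oxygen on an aromatic ring. The same position is involved, and the incoming group is again larger than the cyclobutyl it replaces. For the measured compounds named here, only that one modest step informs the expectation, so for compound 4 in this assay a step of a 1.3-fold higher number from compound 3 to compound 4 (0.12 log units; within the scatter) is expected, either within the scatter or a modest rise. Compound 4 is accordingly estimated at 12 nM, range 4 nM to 40 nM.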

Compound 4, half-maximal inhibitory concentration: 165 nM
The estimate for compound 4 lay 14-fold (1.14 log units) below the measured number; measured number outside the range, above it.
By their numbers in this assay, from the lowest: compound 3; then compound 2; then compound 4; then compound 1.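

In this assay, the position on a saturated chain carbon bound to an oxygen on an aromatic ring is sensitive to the group's shape as well as its heavy-atom count: the step with two five-membered rings is an 18-fold higher number from compound 3 to compound 4 (1.26 log units; beyond the scatter). Heavy-atom count alone does not order the numbers, since compound 4 goes against such a trend with an 8.3-fold higher number from compound 2 to compound 4 (0.92 log units; beyond the scatter), despite its smaller group. Nothing available explains this result. Still open, from the compounds shown here alone, is whether cyclopentyl, cyclohexyl or an amine on that chain carbon would stay close to compound 3.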